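The compounds below may be only part of what the source reports. "The series", "measured", "known", "first", "only" and "open" are said of these compounds alone.

Working notes on the series. Compound 1 `CN(C(=O)NC(=O)c1cccc(C(F)(F)F)c1)c1nc(C(F)(F)F)c(C(=O)N/N=C/c2ccc(C(F)(F)F)cc2)s1` gives 7.71 ug/mL in a functional assay on HepG2 cells (Homo sapiens) for inhibition, read by MTT assay, with a stated time of 72 h; a lower number here means a stronger inhibitor, a higher number a weaker inhibitor. Compound 2 `CN(C(=O)NC(=O)c1cccc(C(F)(F)F)c1)c1nc(C(F)(F)F)c(C(=O)N/N=C/c2ccccc2C(F)(F)F)s1` gives 10.4 ug/mL in this assay; it differs from compound 1 by 2-(trifluoromethyl)phenyl in place of 4-(trifluoromethyl)phenyl on a carbon with a double bond to nitrogen, and the step was a 1.3-fold higher number from compound 1 to compound 2 (0.13 log units; within the scatter). Compound 3 `CN(C(=O)NC(=O)c1c(F)cccc1F)c1nc(C(F)(F)F)c(C(=O)N/N=C/c2ccc(C(F)(F)F)cc2)s1` gives 49.6 ug/mL in this assay; it differs from compound 1 by 2,6-difluorophenyl in place of 3-(trifluoromethyl)phenyl on a carbonyl carbon, and the step was a 6.4-fold higher number from compound 1 to compound 3 (0.81 log units; beyond the scatter), leaving compound 3 at the highest number of the three measured compounds.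

Compound 4 `CN(C(=O)NC(=O)c1c(F)cccc1F)c1nc(C(F)(F)F)c(C(=O)N/N=C/c2ccccc2C(F)(F)F)s1` is not yet measured. It differs from compound 3 by 2-(trifluoromethyl)phenyl in place of 4-(trifluoromethyl)phenyl on a carbon with a double bond to nitrogen. The place of this change is the same, word for word, as in the change from compound 1 to compound 2, so it is the same change, made on the core of compound 3 rather than that of compound 1; how the two cores differ is told above by the difference between compound 1 and compound 3. Because a 1.3-fold higher number from compound 1 to compound 2 (0.13 log units; within the scatter) was within the scatter, a small step is expected here too. The expected step is a 1.3-fold higher number from compound 3 to compound 4 (0.10 log units; within the scatter). For compound 4 the estimate in this assay is 62 ug/mL, likely between 30 ug/mL and 130 ug/mL.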

Compound 4, half-maximal inhibitory concentration: 26.1 ug/mL
Compound 4: the middle estimate sits 2.4-fold (0.38 log units) above what was measured, outside the stated range (below it).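

On the core of compound 3, 2-(trifluoromethyl)phenyl in place of 4-(trifluoromethyl)phenyl on a carbon with a double bond to nitrogen gives a 1.9-fold lower number from compound 3 to compound 4 (0.28 log units; within the scatter) in this assay, and this step stays close to the one seen on the core of compound 1: the same change on two cores in this assay, a 1.3-fold higher number (0.13 log units; within the scatter) from compound 1 to compound 2 and a 1.9-fold lower number (0.28 log units; within the scatter) from compound 3 to compound 4, 2.6-fold (0.41 log units) apart, within the scatter of two such steps.

The other change, 2,6-difluorophenyl in place of 3-(trifluoromethyl)phenyl on a carbonyl carbon, gives a 2.5-fold higher number from compound 2 to compound 4 (0.40 log units; beyond the scatter), so it keeps its direction and stays beyond the scatter on both cores: the same change on two cores in this assay, a 6.4-fold higher number (0.81 log units; beyond the scatter) from compound 1 to compound 3 and a 2.5-fold higher number (0.40 log units; beyond the scatter) from compound 2 to compound 4, 2.6-fold (0.41 log units) apart, within the scatter of two such steps.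

Both changes therefore carried over between these two cores as far as the scatter can tell, but this rests on four compounds in one assay and does not show that either step would hold on any other core, or why the numbers move as they do.

The compounds shown leave open what an amine or a carboxylic acid on either phenyl ring would do to the number. They also leave open whether a methoxy group would behave like the fluorine-bearing groups compared here.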